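The source may report more compounds than this note shows. Statements on the series, on what has been measured and on what is new or still open speak of the compounds shown alone.

Measured compounds:
compound 1, `Cc1cc(NC(=O)c2ccc(Cl)cc2)ccc1NS(=O)(=O)C(F)(F)F`, 35400 nM
compound 2, `Cc1cc(NC(=O)c2ccc(Cl)c([N+](=O)[O-])c2)ccc1NS(=O)(=O)C(F)(F)F`, 89800 nM
compound 3, `CCS(=O)(=O)Nc1ccc(NC(=O)c2ccc(Cl)cc2)cc1OC`, 60100 nM

The three compounds were examined in an ADME assay on RAW264.7 cells (Mus musculus) for cytotoxicity, read by MTT assay, with a stated time of 48 h; on this read-out higher numbers stand for weaker inhibition and lower numbers for stronger inhibition. In this assay compound 1 gives 35400 nM. Compound 2 differs from compound 1 in one place:
nitro in place of hydrogen on an aromatic carbon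
This change gave a 2.5-fold higher number from compound 1 to compound 2 (0.40 log units; beyond the scatter). Compound 3 gives 60100 nM in this assay; the difference between its core and that of compound 1 is not broken down here, and its value sits within the scatter of both compound 1 and compound 2.

Compound 4, `CCS(=O)(=O)Nc1ccc(NC(=O)c2ccc(Cl)c([N+](=O)[O-])c2)cc1OC`, has not yet been measured. It differs from compound 3 in one place:
nitro in place of hydrogen on an aromatic carbon
This is the same change that leads from compound 1 to compound 2, and the surroundings of the place are described in the same words. On that basis the step is expected to be of similar size: from compound 3 to compound 4 an increase of about a 2.3-fold higher number from compound 3 to compound 4 (0.37 log units; beyond the scatter) is estimated, resting on the step of a 2.5-fold higher number from compound 1 to compound 2 (0.40 log units; beyond the scatter) seen with the same change. For compound 4 a value near 140000 nM is therefore expected, plausibly between 70000 nM and 280000 nM.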

Compound 4, half-maximal inhibitory concentration: 5660 nM
Estimate against measurement, compound 4: 25-fold (1.39 log units) above, and the stated range ends above it.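

In this assay nitro in place of hydrogen gave an 11-fold lower number from compound 3 to compound 4 (1.03 log units; beyond the scatter), so on these two cores the step seen on one did not foretell even the direction of the step on the other. This does not show which part of the core decides the direction: the cores of compound 1 and compound 3 differ in more than one place, and two pairs of compounds set no rule for any further core. The two steps stand clearly apart and cannot be treated as one transferable value for this change: the same change on two cores in this assay, a 2.5-fold higher number (0.40 log units; beyond the scatter) from compound 1 to compound 2 and an 11-fold lower number (1.03 log units; beyond the scatter) from compound 3 to compound 4, 27-fold (1.43 log units) apart, beyond the scatter of two such steps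

The compounds shown leave open whether the methyl and trifluoromethyl groups of the core of compound 1, or the methoxy and ethyl groups of the core of compound 3, govern the outcome, as no pair here exchanges one of these alone. From the compounds shown here alone, it also remains open whether an amine or a nitrile in place of the nitro group would follow the same course on each core.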